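Swapping the Sulfonamide Arm for a Small Ring

The compounds below may be only part of what the source reports. "The series", "measured", "known", "first", "only" and "open" are said of these compounds alone.

Compound 1 `COc1ccc(S(=O)(=O)Nc2nc3c(c(=O)n(CC4CC4)c(=O)n3CC3CC3)n2C)cc1` gives 32% in an assay on isolated protein with dual specificity calcium/calmodulin-dependent 3',5'-cyclic nucleotide phosphodiesterase 1B (Bos taurus) as the target, tested at 100 uM; on this read-out higher numbers stand for more inhibition at the one concentration tested (going by the name of the read-out) and lower numbers for less inhibition. Within the data shown here, compound 2 `COc1ccc(S(=O)(=O)Nc2nc3c(c(=O)n(CC4CC4)c(=O)n3CC3CC3)n2Cc2cc(OC)c(OC)c(OC)c2)cc1` gives 52% in this assay, and the step of a number 20 percentage points higher from compound 1 to compound 2 (beyond the scatter) is the only measured step so far. Compound 2 therefore stands highest of the two measured numbers, with compound 1 lying beyond the scatter below it. Compound 3 `COc1cc(Cn2c(/N=C3/CCCN3C)nc3c2c(=O)n(CC2CC2)c(=O)n3CC2CC2)cc(OC)c1OC` carries a change at a different place: a group of 7 heavy atoms (5 carbon, 2 nitrogen; one five-membered non-aromatic ring with 1 hetero atom) in place of a group of 12 heavy atoms (7 carbon, 1 nitrogen, 3 oxygen, 1 sulfur; one six-membered aromatic ring of carbon only), on an aromatic carbon. Among the measured compounds shown here, no measured step touches this place, so the size and direction of a number 12 percentage points lower from compound 2 to compound 3 (beyond the scatter) are expected without direct guidance. Compound 3 is estimated at 40%, with a range from 10% to 75%.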

Compound 3, a percentage reported as inhibition, at one concentration (the size of the read-out at that concentration, not a potency): 48%
The estimate for compound 3 lay 8 percentage points below the measured number; the measured number falls inside the stated range.
By their numbers in this assay, from the lowest: compound 1; then compounds 3 and 2 (each within the scatter of the next).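

At this aromatic carbon between two ring nitrogen atoms, replacing the ((4-methoxyphenyl)sulfonyl)amino group with a smaller group carrying a five-membered non-aromatic ring gives, in this assay, a number 4 percentage points lower from compound 2 to compound 3 (within the scatter). The six-membered aromatic ring and the sulfonyl group of that arm are therefore not required for this level of inhibition in compound 3. No measurement shown here explains this result. On these data alone, it remains open how a simple amine or a carboxylic acid would read at this carbon, and whether the new group would give the same reading with a methyl group on the ring nitrogen, as in compound 1.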